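Toward Compound 3: Expected Tolerance from Two Measured Analogues

The source may report more compounds than this note shows. Statements on the series, on what has been measured and on what is new or still open speak of the compounds shown alone.

Two analogues sharing one core have been tested in an ADME assay on Huh-7 cells (Homo sapiens) for cytotoxicity, read by MTT assay, with a stated time of 48 h; a lower number here means that less compound is tolerated, a higher number that more compound is tolerated. Compound 1 `CN(C)CCCCOC(=O)Nc1ccc(Cn2nc(-c3ccc(C(F)(F)F)cc3)c3ccccc3c2=O)cc1` gives 3360 nM in this assay. Compound 2 `CN(C)CCCCOC(=O)Nc1ccc(Cn2nc(-c3cccc(C(F)(F)F)c3)c3ccccc3c2=O)cc1` gives 11600 nM, the higher of the two numbers, so compound 2 is the better tolerated of the pair. For the measured compounds named here, the only measured step is a 3.5-fold higher number from compound 1 to compound 2 (0.54 log units; beyond the scatter), a change in the position of the trifluoromethyl on the phenyl group. Compound 3 `CN(C)CCCCOC(=O)Nc1ccc(Cn2nc(-c3ccccc3F)c3ccccc3c2=O)cc1` departs from compound 2 by 2-fluorophenyl in place of 3-(trifluoromethyl)phenyl on an aromatic carbon. Going by the values given here, the step from compound 1 to compound 2 bears on this only loosely, since the phenyl group is altered again but the trifluoromethyl is lost altogether, and no measured compound carries a 2-fluorophenyl. A modest change in either direction is therefore plausible, and the expected step is a 1.5-fold lower number from compound 2 to compound 3 (0.16 log units; within the scatter). Compound 3 is estimated at 8000 nM in this assay, with a range from 3000 nM to 25000 nM.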

Compound 3, half-maximal cytotoxic concentration: 52500 nM
Compound 3: the middle estimate sits 6.6-fold (0.82 log units) below what was measured; the whole stated range lies below it.
By their numbers in this assay, from the lowest: compound 1; then compound 2; then compound 3.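

In this assay, the group on this aromatic carbon of the shared core proves able to shift the number well beyond the change seen so far, with a 4.5-fold higher number from compound 2 to compound 3 (0.66 log units; beyond the scatter) and a 16-fold higher number from compound 1 to compound 3 (1.19 log units; beyond the scatter) when 2-fluorophenyl enters. For the compounds shown here, compound 3 is thus the best tolerated of the three, and moving the trifluoromethyl was not the only change here that raised the number: replacing the whole group raised it too. Nothing available explains why this exchange raises the number.

The fluorine, where it sits and the loss of the trifluoromethyl all change together in compound 3, so their shares cannot be separated. From the compounds shown here alone, how a plain phenyl or a chlorophenyl at this carbon would compare remains open.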